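This account rests on a few compounds, and the source may have more. Where it says the series, first, only, none or still open, it means among the compounds named here.

Measured in a functional assay on HCT-116 cells (Homo sapiens) for cytotoxicity, read by MTT assay, with a stated time of 72 h; on this read-out lower numbers stand for stronger inhibition and higher numbers for weaker inhibition:

compound 1 `Cc1cc(-c2ccccc2)n(/C(N)=N/S(=O)(=O)c2cc(C)c(Cl)cc2SCc2cccc3ccccc23)n1`: 7000 nM
compound 2 `Cc1cc(S(=O)(=O)/N=C(\N)n2nccc2-c2ccccc2)c(SCc2ccccc2)cc1Cl`: 12000 nM
compound 3 `Cc1cc(-c2ccccc2)n(/C(N)=N/S(=O)(=O)c2cc(C)c(Cl)cc2SCc2ccccc2)n1`: 10000 nM

Compound 2 stands among three values that all lie within the scatter of each other: the step of a 1.2-fold lower number from compound 2 to compound 3 (0.08 log units; within the scatter) is small, and the gap to compound 1 is also within the scatter, so none of the three can be set apart from the others on this read-out.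

Compound 4 `Cc1cc(S(=O)(=O)/N=C(\N)n2nccc2-c2ccccc2)c(SCc2ccccc2C)cc1Cl` differs from compound 2 by methyl in place of hydrogen on an aromatic carbon. Among the compounds with values here, no measured step changes this ring of the benzylsulfanyl group in the same way. The nearest comparison is a 1.2-fold lower number from compound 2 to compound 3 (0.08 log units; within the scatter), a methyl in place of hydrogen on an aromatic carbon of a different ring, and the change at the benzylic position, a 1.4-fold higher number from compound 1 to compound 3 (0.15 log units; within the scatter), both within the scatter. A methyl added on the benzyl ring is therefore expected to produce no step beyond the scatter in this assay, in either direction.

Compound 4 is estimated at 12000 nM, within 5000 nM to 28000 nM, an expected step of no change at the digits printed from compound 2 to compound 4 (within the scatter).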

Compound 4, half-maximal inhibitory concentration: 16000 nM
For compound 4 the middle estimate is 1.3-fold (0.12 log units) below the measured one, and the stated range covers the measured number.
By their numbers in this assay, from the lowest: compounds 1, 3, 2 and 4 (each within the scatter of the next, the first and the last beyond it).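

In this assay, within the data shown here, the change from benzyl to 2-methylbenzyl gives a 1.3-fold higher number from compound 2 to compound 4 (0.12 log units; within the scatter), the first reading on this ring of the benzylsulfanyl group. A single methyl on an aromatic carbon ortho to a large group therefore leaves the number within the scatter here, as methyl in place of hydrogen on a different ring does in a 1.2-fold lower number from compound 2 to compound 3 (0.08 log units; within the scatter), so this position accepts that one added carbon without a readable step on this read-out. No measurement on hand bears on the reason for this result.

The compounds shown leave open whether a methyl at other places on this ring would also stay within the scatter. Also open, as far as these compounds go, is whether a methoxy group, a chlorine, an amine or a carboxylic acid in the place of this methyl would give a step beyond the scatter.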